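The compounds below may be only part of what the source reports. "The series", "measured", "known", "first", "only" and "open" are said of these compounds alone.

Measured in a functional assay on the whole organism (Tail, strain ICR) with Mus musculus as the target, in the tail flick test, with a stated time of 30 min, at a dose of 25 umol/kg by the oral route; on this read-out lower numbers stand for a weaker effect and higher numbers for a stronger effect at the one dose given:
compound 1 `CC[C@H](C)[C@H](NC(=O)CN(c1ncnc2c1ncn2C1CCCCO1)C1CC1)C(=O)OCc1ccccc1` gives 25.6%
compound 2 `O=C(CN(c1ncnc2c1ncn2C1CCCCO1)C1CC1)N[C@@H](CO)C(=O)OCc1ccccc1` gives 27.8%
compound 3 `O=C(CN(c1ncnc2c1ncn2C1CCCCO1)C1CC1)N[C@@H](CC(=O)OCc1ccccc1)C(=O)OCc1ccccc1` gives 31.8%

Compound 3 has the highest of the three numbers, but its nearest neighbour is compound 2, and the steps of a number 4 percentage points higher from compound 2 to compound 3 (within the scatter) and a number 6.2 percentage points higher from compound 1 to compound 3 (within the scatter) both fall within the scatter, so no ranking among the three can be read from these numbers. The third measured step, a number 2.2 percentage points higher from compound 1 to compound 2 (within the scatter), is likewise within the scatter: three different groups on the saturated chain carbon bound to the amide-type nitrogen and the carbonyl carbon give numbers that cannot be told apart.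

Compound 4 `C[C@H](NC(=O)CN(c1ncnc2c1ncn2C1CCCCO1)C1CC1)C(=O)OCc1ccccc1` is not yet measured. Its difference from compound 3 is hydrogen in place of benzyloxycarbonyl on a saturated chain carbon, two bonds along the chain from an amide-type nitrogen and a carbonyl carbon. The measured step bearing most directly on it is the one in which benzyloxycarbonyl entered at this same place for hydroxy, a number 4 percentage points higher from compound 2 to compound 3 (within the scatter). Removing that group again gives no reason to expect a move beyond the scatter, and the step of a number 6.2 percentage points higher from compound 1 to compound 3 (within the scatter) points the same way. The estimated step is a number 3.8 percentage points lower from compound 3 to compound 4 (within the scatter), with compound 4 expected to give 28%, in the range 15% to 42%.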

Compound 4, a percentage reported as activity, at one dose (the size of the read-out at that dose, not a potency): 55.9%
For compound 4 the middle estimate is 27.9 percentage points below the measured one; the measured number lies above the stated range.
By their numbers in this assay, from the lowest: compounds 1, 2 and 3 (each within the scatter of the next); then compound 4.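

In this assay, within the data shown here, the saturated chain carbon bound to an amide-type nitrogen and a carbonyl carbon proves to be a position where the group does change the read-out, which the earlier compounds could not show: with methyl there, the steps are a number 24.1 percentage points higher from compound 3 to compound 4 (beyond the scatter), a number 28.1 percentage points higher from compound 2 to compound 4 (beyond the scatter) and a number 30.3 percentage points higher from compound 1 to compound 4 (beyond the scatter). The change is not graded across the series, since sec-butyl, hydroxymethyl and (benzyloxycarbonyl)methyl remain within the scatter of one another and, among these four compounds, methyl alone stands apart, with no compound going against this. No supporting measurement is available to account for the separation of compound 4 from the other three.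

Still open, on these data alone, is whether the higher number belongs to methyl specifically or would also appear with a bare hydrogen, an ethyl group or an aminomethyl group on this carbon. Also open, as far as these compounds go, is whether a free carboxylic acid in place of the benzyl ester would keep the number seen with the methyl side chain, as all four compounds carry that ester.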